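A few compounds are considered here, and "the series" means these few. Any claim that something is new, unique, unknown or untested is made for them only; others in the source may bear on it.

Measured compounds in a functional assay on SK-MEL-28 cells (Homo sapiens) for cytotoxicity, read by MTT assay, with a stated time of 96 h; a higher number here means that more compound is needed for the effect, a lower number that less compound is needed:
- compound 1, `N#C/C(=C\c1c(-c2ccccc2)[nH]c2ccccc12)C(=O)c1cccs1`: compound 1 gives 28000 nM
- compound 2, `CCOC(=O)/C(=C/c1c(-c2ccccc2)[nH]c2ccccc12)C(=O)c1ccc([N+](=O)[O-])cc1`: compound 2 gives > 100000 nM, which is a limit of this assay and not a number
- compound 3, `COCCOC(=O)/C(C#N)=C/c1c(-c2ccccc2)[nH]c2ccccc12`: compound 3 gives 9300 nM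

Compound 3 stands lowest of the two numbers shown; the nearest number is that of compound 1, and the step of a 3.0-fold lower number from compound 1 to compound 3 (0.48 log units; beyond the scatter) is the one measured change that bears on the present question. Compound 2 contributes only a limit (the limit of > 100000 nM in this assay, at which 1 of the 3 values shown sits).

The unmeasured compound 4, `N#C/C(=C\c1c(-c2ccccc2)[nH]c2ccccc12)C(=O)c1ccc(Cl)cc1`, differs from compound 3 in one place: 4-chlorophenyl in place of 2-methoxyethoxy on a carbonyl carbon. This change runs opposite to the measured step: there a 2-methoxyethoxy ester replaced a thiophen-2-yl ketone and the number fell by a 3.0-fold lower number from compound 1 to compound 3 (0.48 log units; beyond the scatter); here the same ester gives way to a 4-chlorophenyl ketone. Among the measured compounds shown here, an aryl ketone rather than a thienyl ketone enters, so the match is loose, but the only measured step points to a higher number for compound 4 in this assay, of a size comparable to a 3.0-fold lower number from compound 1 to compound 3 (0.48 log units; beyond the scatter) and beyond the scatter.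

Compound 4 is therefore expected to give about 25000 nM in this assay, within 8000 nM to 80000 nM. The step this estimate means, a 2.7-fold higher number from compound 3 to compound 4 (0.43 log units; beyond the scatter), is expected to be modest and upward.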

Compound 4, half-maximal effective concentration: 15000 nM
The estimate for compound 4 lay 1.7-fold (0.22 log units) above the measured number; measured number inside the range.
By their numbers in this assay, from the lowest: compounds 3, 4 and 1 (each within the scatter of the next, the first and the last beyond it). At a limit, above all of these: compound 2.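

In this assay, replacing the 2-methoxyethoxy ester with a 4-chlorophenyl ketone on this carbonyl carbon gives a 1.6-fold higher number from compound 3 to compound 4 (0.21 log units; within the scatter), so this change cannot be told from scatter, and the ester does not stand apart from this aryl ketone. Exchanging thiophen-2-yl for 4-chlorophenyl on the same carbon gives a 1.9-fold lower number from compound 1 to compound 4 (0.27 log units; within the scatter), so the two ketones also cannot be separated; the earlier step of a 3.0-fold lower number from compound 1 to compound 3 (0.48 log units; beyond the scatter) therefore does not establish a general difference between esters and ketones, since compound 4 is a ketone that lies within the scatter of both compound 1 and compound 3. No measured property among the data shown bears on these steps.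

Going by these compounds, what an amide on this carbonyl carbon, or a carboxylic acid or longer ether chain in place of 2-methoxyethoxy, would do to the number stays open. Compound 2 adds no number for comparison, as its value is a limit of the assay: the limit of > 100000 nM in this assay, at which 1 of the 4 values shown sits.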